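The compounds below may be only part of what the source reports. "The series", "measured", "known", "first", "only" and "open" are said of these compounds alone.

Within the data shown here, in an ADME assay on the whole organism for inhibition, with Echinochloa crus-galli var. formosensis as the target (on this read-out lower numbers stand for stronger inhibition and higher numbers for weaker inhibition), compound 1 `CCN(CC)c1nc(Cl)nc(NC(C)c2ccccc2)n1` gives 17800 nM, the higher of the two numbers so far, while compound 2 `CCNc1nc(Cl)nc(N[C@H](C)c2ccccc2)n1` gives 174 nM, a gap well beyond the usual scatter of repeat measurements. Compound 3 `CCN(CC)c1nc(Cl)nc(N[C@H](C)c2ccccc2)n1` is the next to be measured in this assay. The change from compound 1 is small on paper: the two compounds have the same atoms and bonds; at least one stereo element is drawn with a configuration in one of them and without one in the other: 1 of 1 stereo elements differ; a stereocentre at a saturated chain carbon is drawn without a configuration in compound 1 and R in compound 3. A stereocentre at a saturated chain carbon is drawn without a configuration in compound 1 and R in compound 3. Among the measured compounds shown here, a drawing without a configuration may stand for a mixture of both mirror forms, although the data do not say so, and no measured pair here shows what fixing such a centre does. If compound 1, at 17800 nM, is such a mixture, then a single form should sit near it, probably somewhat lower if that form carries the activity. The expected change is a modest drop, a 2.0-fold lower number from compound 1 to compound 3 (0.30 log units; within the scatter), which may not clear the scatter. The estimate for compound 3 is 9000 nM, with an expected range from 3500 nM to 20000 nM.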

Compound 3, half-maximal inhibitory concentration: 21400 nM
The estimate for compound 3 lay 2.4-fold (0.38 log units) below the measured number; the whole stated range lies below it.
By their numbers in this assay, from the lowest: compound 2; then compounds 1 and 3 (each within the scatter of the next).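

In this assay, drawing the stereocentre at the saturated chain carbon as R makes no readable difference, with a 1.2-fold higher number from compound 1 to compound 3 (0.08 log units; within the scatter). That puts the configuration at this centre on the same footing in compound 2 and compound 3, so the large gap seen earlier can now be read as a change in one place, ethyl in place of hydrogen on a nitrogen on an aromatic ring, with a 120-fold higher number from compound 2 to compound 3 (2.09 log units; beyond the scatter); compound 2, with the hydrogen, is the stronger inhibitor on this read-out. The flat result for the stereocentre rests on a pair that differs in a single feature: the fact that one of compounds 1 and 3 is drawn with a defined configuration and the other without, at the place where they differ

The compounds shown leave open what the mirror form with an S centre would give, and whether compound 1 is a mixture of both forms at all. They also leave open how a methyl group or a longer chain such as propyl would read in place of that second ethyl on the nitrogen, and so whether the loss depends on the size of the group there.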